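The compounds below may be only part of what the source reports. "The series", "measured", "known", "first", "only" and "open" are said of these compounds alone.

Measured in a functional assay on HeLa cells (Homo sapiens) for antiproliferative activity, read by MTT assay, with a stated time of 48 h; a higher number here means a weaker inhibitor, a lower number a stronger inhibitor:

Compound 1 `Brc1ccc(CSc2nnc(-c3cnccn3)s2)cc1`: 12400 nM
Compound 2 `Clc1cccc(CSc2nnc(-c3cnccn3)n2-c2ccccc2)c1`: 13500 nM
Compound 3 `Brc1cccc(CSc2nnc(-c3cnccn3)n2-c2ccccc2)c1`: 9580 nM

These three values sit close together. Compound 3, at 9580 nM, lies within the usual scatter of both other compounds, so the numbers do not separate it from them.

The next compound, compound 4 `Brc1ccc(CSc2nnc(-c3cnccn3)n2-c2ccccc2)cc1`, differs from compound 3 in one place: 4-bromophenyl in place of 3-bromophenyl on a saturated chain carbon bound to a sulfur. In words, this is 4-bromophenyl in place of 3-bromophenyl on a saturated chain carbon bound to a sulfur.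

For the measured compounds named here, only one measured step links two compounds that differ in one place: a 1.4-fold lower number from compound 2 to compound 3 (0.15 log units; within the scatter). That step exchanges chloro for bromo on an aromatic carbon, so it stays small but does not test the new change. Going by the values given here, no measured pair shows directly what this change does. The nearest hint is compound 1, which carries the same 4-bromobenzyl group on a different core and gives 12400 nM, close to the value of compound 3.

No step beyond the scatter is therefore expected in this assay. The estimated change is a 1.1-fold higher number from compound 3 to compound 4 (0.04 log units; within the scatter). For compound 4 the expected value is 10500 nM, with an estimated range of 5500 nM to 20000 nM.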

Compound 4, half-maximal inhibitory concentration: 8630 nM
Compound 4: the middle estimate sits 1.2-fold (0.09 log units) above what was measured; the measured number falls inside the stated range.
By their numbers in this assay, from the lowest: compounds 4, 3, 1 and 2 (each within the scatter of the next).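

In this assay, for the compounds shown here, exchanging 3-bromophenyl for 4-bromophenyl on a saturated chain carbon bound to a sulfur gives a 1.1-fold lower number from compound 3 to compound 4 (0.05 log units; within the scatter), the direct pair that the earlier compounds lacked, and it shows that these two arrangements of the same atoms cannot be told apart in this assay. Changing the halogen and its place together, with 3-chlorophenyl giving way to 4-bromophenyl, gives a 1.6-fold lower number from compound 2 to compound 4 (0.19 log units; within the scatter), so even this double change on the benzyl group does not separate the compounds. Nothing available here explains why these changes leave the number within the scatter.

Every group at this position in the compounds shown is a benzyl ring carrying one bromine or chlorine, so these results say nothing about how a ring bearing an amine, a carboxylic acid or a methoxy group would behave. It also remains open whether a longer chain between the sulfur and the ring would move the number beyond the scatter, which none of the steps shown has done so far.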